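The source may hold more compounds than are shown below. What is called first, only, known or untested is meant among the compounds shown, and "the series" means these compounds.

For the measured compounds named here, compound 2 `O=C(CC1CCCC1)Nc1c(C(O)(C(F)(F)F)C(F)(F)F)ccc2ccccc12` gives 81 nM in an assay on LtK cells with ATP-sensitive inward rectifier potassium channel 11 (Homo sapiens) as the target (a higher number here means that more compound is needed for the effect, a lower number that less compound is needed), the lowest of the two numbers measured so far. Going by the values given here, its only measured neighbour is compound 1 `O=C(Nc1c(C(O)(C(F)(F)F)C(F)(F)F)ccc2ccccc12)C1CCCC1`, which in this assay gives 495 nM; the single measured step is a 6.1-fold lower number from compound 1 to compound 2 (0.79 log units; beyond the scatter), a change made at the carbonyl carbon of the amide.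

Compound 3 `O=C(Nc1c(C(O)(C(F)(F)F)C(F)(F)F)ccc2ccccc12)c1cccc(Br)c1` carries the next change at that same carbonyl carbon: 3-bromophenyl in place of cyclopentylmethyl on a carbonyl carbon. Among the compounds with values here, no measured step bears directly on this replacement. Within the data shown here, the one step that exists compares a cyclopentyl ring with a cyclopentylmethyl group, and it shows that what sits on this carbonyl carbon can move the number in this assay by a good margin. A 3-bromophenyl group resembles neither of those groups, so the direction of the change cannot be read from the measured compounds, and the expectation is built around compound 2 with wide uncertainty. The step expected in this assay is a 1.9-fold higher number from compound 2 to compound 3 (0.27 log units; within the scatter), which is not clearly beyond the scatter. The estimate for compound 3 in this assay is 150 nM, with a range from 30 nM to 800 nM.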

Compound 3, half-maximal effective concentration: 80 nM
Compound 3: the middle estimate sits 1.9-fold (0.27 log units) above what was measured, and the stated range covers the measured number.
By their numbers in this assay, from the lowest: compounds 3 and 2 (each within the scatter of the next); then compound 1.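

The step of a 1.0-fold lower number from compound 2 to compound 3 (0.01 log units; within the scatter) shows that in this assay a six-membered aromatic ring carrying bromine and a five-membered non-aromatic ring held on one extra carbon cannot be told apart at this carbonyl carbon. The step of a 6.2-fold lower number from compound 1 to compound 3 (0.79 log units; beyond the scatter) sets the 3-bromophenyl group clearly apart from the cyclopentyl group, which leaves compound 1 as the only one of the three separated from the others, so aromatic character alone does not decide the number: compound 1 and compound 2 both carry the same kind of ring, yet only compound 2 and compound 3 lie within the scatter of each other. Nothing available explains why these groups on the carbonyl carbon give the numbers they do.

The compounds shown leave open what the bromine contributes, and whether a plain phenyl or a 3-chlorophenyl group on this carbonyl carbon would give a number like that of compound 3. Also open, as far as these compounds go, is how a benzyl group or a longer chain such as cyclopentylethyl would compare with the cyclopentylmethyl group of compound 2.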